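A few compounds are considered here, and "the series" means these few. Any claim that something is new, unique, unknown or untested is made for them only; others in the source may bear on it.

Measured compounds:
Compound 1, `Cc1ccc(S(=O)(=O)N[C@@H](CC(=O)NC(C)(C)C)C(=O)NCCNC(=O)c2ccccc2)cc1`, gives > 11100 nM in an ADME assay on Karpas-1106P cells (Homo sapiens) for cytotoxicity; a lower number here means that less compound is needed, a higher number that more compound is needed for the effect.
Compound 2, `Cc1ccc(S(=O)(=O)N[C@@H](CC(=O)NC(C)(C)C)C(=O)NCCNC(=O)c2c(O)cccc2F)cc1`, gives > 11100 nM in this assay.

Both of these values are limits of the assay rather than numbers, so neither compound has a measured concentration. For compound 1 only a limit is known. For compound 2 only a limit is known as well. The two values sit at the same point, (the limit of > 11100 nM in this assay, at which 2 of the 2 values shown sit), and the step that the two limits leave unreadable from compound 1 to compound 2 is accordingly unreadable in size and direction.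

Compound 3, `C#Cc1cccc(C(=O)NCCNC(=O)[C@H](CC(=O)NC(C)(C)C)NS(=O)(=O)c2ccc(C)cc2)c1`, differs from compound 1 by ethynyl in place of hydrogen on an aromatic carbon. Among the measured compounds shown here, no measured step touches this position, and the single measured step in this assay is itself unreadable, so there is no basis for expecting a change beyond the scatter. The step that the limit leaves unreadable from compound 1 to compound 3 is therefore expected to be small or absent. Compound 3 is estimated at 20000 nM, with a range from 8000 nM to 60000 nM, most likely reported again only as a limit.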

Compound 3, half-maximal effective concentration: > 11100 nM
Compound 3 gave a limit, no number; the forecaster's own chance of this, stated with the estimate: 80%; the middle value does not contradict the limit.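

Compound 3 also gives only a limit, so no step between it and compound 1 or compound 2 can be read, in size or direction, as all three sit at the same point: the limit of > 11100 nM in this assay, at which 3 of the 3 values shown sit.

The compounds shown leave open how compound 1, compound 2 and compound 3 truly compare in this assay.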